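Methyl on the Aromatic Nitrogen of Compound 1

A few compounds are considered here, and "the series" means these few. Any claim that something is new, unique, unknown or untested is made for them only; others in the source may bear on it.

Compound 1 `O=C(NNC(=O)c1cc([N+](=O)[O-])c[nH]1)Nc1ccc([N+](=O)[O-])cc1` was tested in an ADME assay on Vero cells (Chlorocebus sabaeus) for cytotoxicity, read by MTT assay, with a stated time of 72 h (on this read-out lower numbers stand for stronger inhibition and higher numbers for weaker inhibition), where compound 1 gives 211000 nM. Of the two numbers in hand this is the lower, but compound 2 `O=C(NNC(=S)NCc1ccccc1)c1cc([N+](=O)[O-])c[nH]1` gives 397000 nM, and that gap lies within the scatter of this assay, so the two cannot be told apart. Compound 3 `Cn1cc([N+](=O)[O-])cc1C(=O)NNC(=O)Nc1ccc([N+](=O)[O-])cc1` differs from compound 1 by methyl in place of hydrogen on an aromatic nitrogen. Going by the values given here, no measured pair shows the effect of such a change, so compound 3 is expected to show a 1.2-fold higher number from compound 1 to compound 3 (0.07 log units; within the scatter), no step beyond the scatter. Compound 3 is estimated at 250000 nM, with a range from 100000 nM to 600000 nM.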

Compound 3, half-maximal inhibitory concentration: 402000 nM
Compound 3: middle estimate off by 1.6-fold (0.21 log units), on the low side, within the range that was stated.
By their numbers in this assay, from the lowest: compounds 1, 2 and 3 (each within the scatter of the next).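

In this assay, methyl in place of hydrogen on the aromatic nitrogen gives a 1.9-fold higher number from compound 1 to compound 3 (0.28 log units; within the scatter), the first step read at this position. The hydrogen on this nitrogen can therefore be replaced by methyl without a step beyond the scatter in this cytotoxicity read-out. Nothing at hand bears on why this is so.

The compounds shown leave open whether a longer chain such as ethyl, or a chain carrying an amine or a carboxylic acid, on this nitrogen would give a step beyond the scatter. They also leave open whether methyl at this position would give a similar step from compound 2.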